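The source may hold more compounds than are shown below. What is called first, only, known or untested is meant among the compounds shown, and "the series" means these compounds.

Three compounds built on one shared core were tested in a functional assay on NCI-H1975 cells (Homo sapiens) for antiproliferative activity, read by MTT assay, with a stated time of 72 h; a higher number here means a weaker inhibitor, a lower number a stronger inhibitor. Compound 1 `COc1cc(F)c(NC(=O)c2ccnc(O)c2)cc1Nc1nccc(-c2cn(C)c3ccccc23)n1` gives 5920 nM. Compound 2 `COc1cc(N(C)CCN(C)C)c(NC(=O)c2ccncc2)cc1Nc1nccc(-c2cn(C)c3ccccc23)n1` gives 6860 nM, while compound 3 `COc1cc(N(C)CCN(C)C)c(NC(=O)c2ccnc(Cl)c2)cc1Nc1nccc(-c2cn(C)c3ccccc23)n1` gives 2050 nM, the lowest number of the three, with compound 1 nearest to it. For the measured compounds named here, the only single change measured is the step of a 3.3-fold lower number from compound 2 to compound 3 (0.52 log units; beyond the scatter). Compound 4 `COc1cc(N(C)CCN(C)C)c(NC(=O)c2ccnc(O)c2)cc1Nc1nccc(-c2cn(C)c3ccccc23)n1` differs from compound 3 by hydroxy in place of chloro on an aromatic carbon. Going by the values given here, no measured pair carries this exact change; compound 1 also bears the hydroxy but differs from compound 3 elsewhere as well, so their two values merely hint that the hydroxy form sits higher. Compound 4 is therefore expected to move by a 2.2-fold higher number from compound 3 to compound 4 (0.34 log units; beyond the scatter), giving an estimated 4500 nM, with a range from 1800 nM to 11000 nM.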

Compound 4, half-maximal inhibitory concentration: 12000 nM
Estimate against measurement, compound 4: 2.7-fold (0.43 log units) below; the measured number lies above the stated range.
By their numbers in this assay, from the lowest: compound 3; then compounds 1, 2 and 4 (each within the scatter of the next, the first and the last beyond it).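

In this assay, hydroxy in place of chloro on the aromatic carbon next to the ring nitrogen gives a 5.9-fold higher number from compound 3 to compound 4 (0.77 log units; beyond the scatter) and thus removes the advantage chloro had shown, while hydroxy in place of hydrogen gives a 1.7-fold higher number from compound 2 to compound 4 (0.24 log units; within the scatter) and so makes no clear difference. With hydroxy held constant, (2-(dimethylamino)ethyl)(methyl)amino in place of fluoro gives a 2.0-fold higher number from compound 1 to compound 4 (0.31 log units; beyond the scatter) as a modest step. No evidence is available to explain these differences. On these data alone, whether an amine, a methoxy group or bromo at this carbon would match chloro remains open. So does whether the fluoro exchange would behave alike with chloro on the pyridine.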